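Swapping Methyl for tert-Butyl on Two Related Cores

This account rests on a few compounds, and the source may have more. Where it says the series, first, only, none or still open, it means among the compounds named here.

Three compounds have been measured in a functional assay on A549 cells (Homo sapiens) for inhibition, read by sulforhodamine B assay; on this read-out higher numbers stand for weaker inhibition of growth and lower numbers for stronger inhibition of growth:
compound 1 `Cc1ccc(OCc2ccccc2)c(/C=C2\SC(=S)NC2=O)c1` gives 6000 nM;
compound 2 `CC(C)(C)c1ccc(OCc2ccccc2)c(/C=C2\SC(=S)NC2=O)c1` gives 7000 nM;
compound 3 `Cc1ccc(OCc2ccccc2)c(/C=C2\SC(=O)NC2=O)c1` gives 8000 nM.

Compound 2 arises from compound 1 by a single change, (tert-butyl in place of methyl on an aromatic carbon), and the step it made is a 1.2-fold higher number from compound 1 to compound 2 (0.07 log units; within the scatter). Compound 3 carries the same methyl-bearing ring as compound 1 but a different core; the difference between the two cores is not broken down here. The values of compound 3 and compound 1 lie within the scatter of each other, and so do those of compound 3 and compound 2, so no order among the three can be read from them.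

Compound 4 `CC(C)(C)c1ccc(OCc2ccccc2)c(/C=C2\SC(=O)NC2=O)c1` has not yet been measured. It arises from compound 3 by tert-butyl in place of methyl on an aromatic carbon, the same change that leads from compound 1 to compound 2, made at the same place on the ring. Because the earlier step of a 1.2-fold higher number from compound 1 to compound 2 (0.07 log units; within the scatter) stayed within the scatter, the step from compound 3 to compound 4 is expected to be similarly small, a 1.1-fold higher number from compound 3 to compound 4 (0.05 log units; within the scatter). Compound 4 is therefore estimated to give 9000 nM in this assay, most likely between 4500 nM and 18000 nM.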

Compound 4, concentration for 50% growth inhibition: 2000 nM
The estimate for compound 4 lay 4.5-fold (0.65 log units) above the measured number; the measured number lies below the stated range.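

In this assay, tert-butyl in place of methyl gives a 4.0-fold lower number from compound 3 to compound 4 (0.60 log units; beyond the scatter), and exchanging the core while tert-butyl stays in place gives a 3.5-fold lower number from compound 2 to compound 4 (0.54 log units; beyond the scatter). The change therefore does not carry over unchanged from one core to the other, as the two steps differ: the same change on two cores in this assay, a 1.2-fold higher number (0.07 log units; within the scatter) from compound 1 to compound 2 and a 4.0-fold lower number (0.60 log units; beyond the scatter) from compound 3 to compound 4, 4.7-fold (0.67 log units) apart, beyond the scatter of two such steps

Within these four compounds, the outcome of this change depends on the core it is made on, but this rests on a single pair of steps and does not show why the cores differ or what would happen on a third core.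

The compounds shown leave open whether the stronger inhibition seen with compound 4 is special to tert-butyl or would also appear with another group in the same place on the ring, such as ethyl, isopropyl, chlorine or an amine. They also leave open whether the same dependence on the core would appear in other cell lines.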